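Cyclobutyl gives way to tert-butyl on the ether chain

The compounds below may be only part of what the source reports. "The series", "measured", "known", "first", "only" and "open" are said of these compounds alone.

In a physicochemical assay for solubility (on this read-out higher numbers stand for higher solubility and lower numbers for lower solubility), compound 2 (`CS(=O)(=O)c1ccc(-n2nc(C(F)(F)F)cc2OCC2CCC2)cc1`) gives 25 ug/mL and stands level with compound 1 (`CS(=O)(=O)c1ccc(-n2nc(C(F)(F)F)cc2OC2CCCC2)cc1`) at 25 ug/mL on this measure. Compound 3 (`CC(C)(C)COc1cc(C(F)(F)F)nn1-c1ccc(S(C)(=O)=O)cc1`) carries tert-butyl in place of cyclobutyl on a saturated chain carbon bound to an oxygen on an aromatic ring. Among the measured compounds shown here, the one measured step that bears on this, cyclobutylmethyl in place of cyclopentyl, showed no change at the digits printed from compound 1 to compound 2 (within the scatter) but kept a ring in both compounds. No step beyond the scatter is therefore expected in this assay here. The estimated step is a 1.3-fold lower number from compound 2 to compound 3 (0.10 log units; within the scatter) and no more. Compound 3 is expected at 20 ug/mL with a range from 9 ug/mL to 45 ug/mL in this estimate.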

Compound 3, solubility: 50 ug/mL
Compound 3: the middle estimate sits 2.5-fold (0.40 log units) below what was measured, outside the stated range (above it).
By their numbers in this assay, from the lowest: compounds 1, 2 and 3 (each within the scatter of the next).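

In this assay, a group with no ring now stands at this place, on a saturated chain carbon bound to an oxygen on an aromatic ring: tert-butyl in place of cyclobutyl gives a 2.0-fold higher number from compound 2 to compound 3 (0.30 log units; within the scatter). Neopentyl in place of cyclopentyl on the oxygen gives a 2.0-fold higher number from compound 1 to compound 3 (0.30 log units; within the scatter), so neither step that removes the ring goes beyond the scatter. No measurement shown bears on the cause of these numbers. The compounds shown leave open whether an amine, a carboxylic acid or a longer chain at this place would give a step beyond the scatter.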